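Pentyl in Place of 1-Phenylethyl on an Acylguanidine

The source may report more compounds than this note shows. Statements on the series, on what has been measured and on what is new or still open speak of the compounds shown alone.

Compound 1, `Cc1nc(N)sc1CCCN/C(N)=N/C(=O)N[C@H](C)c1ccccc1`: 17.8 nM
Compound 2, `N/C(=N\C(=O)NCc1ccccc1)NC1CCc2nc(N)sc2C1`: 513 nM
Compound 3, `Cc1nc(N)sc1CCCN/C(N)=N/C(=O)NC(c1ccccc1)c1ccccc1`: 43.7 nM

In an assay on membranes from Sf9 cells for displacement of a labelled ligand from histamine H2 receptor (Homo sapiens), read by scintillation counting, with a stated time of 60 min (on this read-out lower numbers stand for stronger inhibition and higher numbers for weaker inhibition), compound 1 gives 17.8 nM, the lowest number of the three. Compound 3 gives 43.7 nM, a gap beyond the scatter, and compound 2 gives 513 nM, far weaker. Compound 4, `CCCCCNC(=O)/N=C(\N)NCCCc1sc(N)nc1C`, has not been measured in this assay. It differs from compound 1 in one place: pentyl in place of 1-phenylethyl on an amide-type nitrogen. Going by the values given here, no pair of measured compounds shows this change, so its size is not known from the data. Since compound 1 and compound 3 both keep an aromatic ring at this nitrogen and compound 4 has none, a moderate rise in the number is expected, with the step from compound 1 to compound 4 estimated at a 2.8-fold higher number from compound 1 to compound 4 (0.45 log units; beyond the scatter). Compound 4 is thus expected to give 50 nM, within 15 nM to 180 nM.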

Compound 4, inhibition constant: 4.47 nM
For compound 4 the middle estimate is 11-fold (1.05 log units) above the measured one, outside the stated range (below it).
By their numbers in this assay, from the lowest: compound 4; then compound 1; then compound 3; then compound 2.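

In this assay putting pentyl in place of 1-phenylethyl on the amide-type nitrogen brings a 4.0-fold lower number from compound 1 to compound 4 (0.60 log units; beyond the scatter) and so shows that a low number at this position needs neither an aromatic ring nor a defined stereocentre. On the core of compound 1, an open carbon chain does better here than the group it replaces. Nothing available explains this change.

From the compounds shown here alone, whether a butyl or hexyl chain, or a pentyl chain ending in an amine, would go lower still remains open. So does whether pentyl would bring a similar step on the core of compound 2.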